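The source may hold more compounds than are shown below. What is called first, only, known or untested is meant among the compounds shown, and "the series" means these compounds.

Series notes: thiosemicarbazide-type compounds tested in a functional assay on MCF7 cells (Homo sapiens) for cytotoxicity, read by MTT assay, with a stated time of 72 h, tested at 3 uM; on this read-out lower numbers stand for less inhibition of growth and higher numbers for more inhibition of growth at the one concentration tested.

Compound 1 `N/C(=N\NC(=S)N1CCCCC1)c1ccccn1` gives 38.6% in this assay. Compound 2 `N/C(=N\NC(=S)N1CCCC1)c1ccccn1` differs from compound 1 by pyrrolidin-1-yl in place of piperidin-1-yl on a thiocarbonyl carbon; in this assay compound 2 gives 49.8%; the step is a number 11.2 percentage points higher from compound 1 to compound 2 (beyond the scatter). Compound 3 `Cc1ccnc(/C(N)=N/NC(=S)N2CCCCC2)c1` carries the change methyl in place of hydrogen on an aromatic carbon relative to compound 1; in this assay compound 3 gives 29.4%; the step is a number 9.2 percentage points lower from compound 1 to compound 3 (within the scatter), so the values of compound 1 and compound 3 cannot be ordered. Compound 3 stands furthest from compound 2, and that gap is beyond the scatter.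

Compound 4 `Cc1ccnc(/C(N)=N/NC(=S)N2CCCC2)c1` is not yet measured. It differs from compound 3 by pyrrolidin-1-yl in place of piperidin-1-yl on a thiocarbonyl carbon. For the measured compounds named here, this is the same change as the one from compound 1 to compound 2: the place lines agree word for word, a thiocarbonyl carbon whose other neighbours are an amide-type nitrogen. The two cores differ by methyl in place of hydrogen on an aromatic carbon, which on its own moved the read-out only within the scatter.

The expectation for compound 4 therefore rests on a single prior instance of the change. Because the earlier step was a number 11.2 percentage points higher from compound 1 to compound 2 (beyond the scatter), the step from compound 3 to compound 4 is estimated at a number 10.6 percentage points higher from compound 3 to compound 4 (beyond the scatter), of similar size and direction. Going by the values given here, with only one example, the range is kept wide. Compound 4 is expected to give about 40% in this assay, most likely between 28% and 53%.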

Compound 4, percent growth inhibition at one concentration: 57.7%
Beside the measured number, compound 4's estimate is 17.7 percentage points below it; the whole stated range lies below it.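

In this assay, pyrrolidin-1-yl in place of piperidin-1-yl on a thiocarbonyl carbon gives a step in the same direction on both cores, here a number 28.3 percentage points higher from compound 3 to compound 4 (beyond the scatter), but its size does not carry over unchanged: the same change on two cores in this assay, a number 11.2 percentage points higher (beyond the scatter) from compound 1 to compound 2 and a number 28.3 percentage points higher (beyond the scatter) from compound 3 to compound 4, 17.1 percentage points apart, beyond the scatter of two such steps

The matching comparison for methyl in place of hydrogen on an aromatic carbon is a number 7.9 percentage points higher from compound 2 to compound 4 (within the scatter), so compound 2 and compound 4 cannot be ordered, although that step and its counterpart on the other core do differ: the same change on two cores in this assay, a number 9.2 percentage points lower (within the scatter) from compound 1 to compound 3 and a number 7.9 percentage points higher (within the scatter) from compound 2 to compound 4, 17.1 percentage points apart, beyond the scatter of two such steps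

The four compounds therefore support carrying the direction of the ring change between these two cores, but not its size, and the two changes do not simply add; they do not show why the step is larger on the methyl core, or that the direction would hold on any further core.

Still open, going by these compounds, is whether the larger step on the methyl core extends to other amines on the thiocarbonyl carbon, such as morpholin-4-yl or an open-chain dimethylamino group. On these data alone, it is equally open whether a chlorine or a methoxy group in place of the methyl would give a step of the size seen on the core of compound 1 or of the size seen on the core of compound 3.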